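The source may hold more compounds than are shown below. What is called first, only, known or untested is meant among the compounds shown, and "the series" means these compounds.

Compound 1 `CCN(CC)C(=O)CC1CCc2cc(OC)c(OC)cc21` gives 31.3% in a functional assay on the whole organism (strain Wistar) for inhibition, with Rattus norvegicus as the target, read by paw edema, with stated times of 60 min and 1 h, at a dose of 100 mg/kg by the oral route; on this read-out lower numbers stand for less inhibition and higher numbers for more inhibition at the one dose given (going by the name of the read-out).
Compound 2 `COc1cc2c(cc1OC)C(CC(=O)NC1CCCCC1)CC2` gives 50% in this assay.

Of these two numbers compound 2 holds the higher; the nearest, compound 1, lies lower, the step being a number 18.7 percentage points higher from compound 1 to compound 2 (beyond the scatter). That step exchanges the group on the carbonyl carbon and is the only measured one so far.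

Compound 3 `COc1cc2c(cc1OC)C(CC(=O)NCc1ccccc1)CC2` differs from compound 2 by benzyl in place of cyclohexyl on an amide-type nitrogen. Among the compounds with values here, no measured step bears on this exact exchange; the one step known concerns a different replacement at the same position and shows that the group on the amide nitrogen can move the read-out in this assay by a modest amount. Compound 3 is therefore expected to sit close to compound 2, with a step of a number 5 percentage points lower from compound 2 to compound 3 (within the scatter) that stays within the scatter. For compound 3 the estimated value in this assay is 45%, with a range from 25% to 65%.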

Compound 3, a percentage reported as inhibition, in the whole organism at one dose (the size of the read-out at that dose, not a potency): 18.8%
Compound 3: the middle estimate sits 26.2 percentage points above what was measured; measured number outside the range, below it.
By their numbers in this assay, from the lowest: compound 3; then compound 1; then compound 2.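

Compound 3 shows that the group on the amide-type nitrogen can do more in this assay than the first step suggested: exchanging one six-membered ring group for another, with benzyl in place of cyclohexyl, gives a number 31.2 percentage points lower from compound 2 to compound 3 (beyond the scatter). The benzylamino group also falls short of the open-chain diethylamino group, with a number 12.5 percentage points lower from compound 1 to compound 3 (beyond the scatter), so among these three groups on the carbonyl carbon, the order of the read-out does not simply follow the presence of a ring. No measured evidence accounts for the size or direction of these steps.

Benzyl differs from cyclohexyl both in its aromatic ring and in its extra carbon, and these compounds cannot tell which of the two goes with the lower number. Cyclohexylmethyl or phenyl on the amide-type nitrogen would separate the two.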